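The source may hold more compounds than are shown below. What is called first, only, known or untested is meant among the compounds shown, and "the series" means these compounds.

Working notes on the series.

Compound 1 `Cc1nc(C)c([C@H](OC(C)(C)C)C(=O)O)c(N2CCC(C)(C)CC2)c1-c1ccc(Cc2ccccc2)cc1` is the parent. In a toxicity assay on MT2 cells (Homo sapiens) for cytotoxicity, read by XTT assay, with a stated time of 4 days (on this read-out lower numbers stand for higher toxicity in this test and higher numbers for lower toxicity in this test), compound 1 gives >= 20000 nM, which is a limit of the assay and not a number. Compound 2 `Cc1ccc(CCOc2ccc(-c3c(C)nc(C)c([C@H](OC(C)(C)C)C(=O)O)c3N3CCC(C)(C)CC3)cc2)cc1` gives >= 33500 nM, again a limit. Compound 3 `Cc1nc(C)c([C@H](OC(C)(C)C)C(=O)O)c(N2CCC(C)(C)CC2)c1-c1ccc(OCCCc2ccc(F)cc2)cc1` gives >= 32000 nM, also a limit. Going by the values given here, the steps a step that the two limits leave unreadable from compound 1 to compound 2, a step that the two limits leave unreadable from compound 1 to compound 3 and a step that the two limits leave unreadable from compound 2 to compound 3 are therefore all unreadable; the three values sit at the limit of >= 20000 nM in this assay, at which 1 of the 3 values shown sits, the limit of >= 32000 nM in this assay, at which 1 of the 3 values shown sits, and (the limit of >= 33500 nM in this assay, at which 1 of the 3 values shown sits), so no step has a measurable size, and no ranking within the three can be made.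

Compound 4 `Cc1nc(C)c([C@H](OC(C)(C)C)C(=O)O)c(N2CCC(C)(C)CC2)c1-c1ccc(SCCc2ccc(F)cc2)cc1` is not yet measured. It differs from compound 1 by (2-(4-fluorophenyl)ethyl)sulfanyl in place of benzyl on an aromatic carbon. The steps bearing on it are those from compound 1, a step that the two limits leave unreadable from compound 1 to compound 2 and a step that the two limits leave unreadable from compound 1 to compound 3, and both are unreadable. Among the compounds with values here, no measured step shows any change beyond the scatter, and the expectation is that compound 4 also shows no change beyond the scatter, with the step that the limit leaves unreadable from compound 1 to compound 4 meant only as a working assumption. Compound 4 is estimated at 30000 nM, with a range of 15000 nM to 60000 nM, and most likely reported as a limit.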

Compound 4, half-maximal cytotoxic concentration: >= 32000 nM
Compound 4 ended at the assay's limit (the forecaster's own chance of this, stated with the estimate: 85%); middle value at least 1.0-fold (0.02 log units) away from the limit.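

Compound 4 gives >= 32000 nM, a limit of the assay and not a number. Compound 1, compound 2 and compound 3 also stand at limits, so none of their steps to compound 4 can be read. The compounds shown leave open whether any of these four differs from the others in this assay.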